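The source may hold more compounds than are shown below. What is called first, only, known or untested is meant among the compounds shown, and "the series" means these compounds.

Three compounds built on one shared core, each carrying a different group on a carbonyl carbon, have been tested in an assay on HEK293 cells for negative allosteric modulation of metabotropic glutamate receptor 5 (Homo sapiens), read by FLIPR, with a stated time of 1 h; on this read-out lower numbers stand for stronger inhibition and higher numbers for weaker inhibition. Compound 1 `CC1CC1C(=O)N1CCc2nc(C#Cc3ccccc3)sc2C1` carries a 2-methylcyclopropyl group there, and in this assay compound 1 returns only a limit of the assay, > 10000 nM, not a number. Compound 2 `CC1CCCC(C(=O)N2CCc3nc(C#Cc4ccccc4)sc3C2)C1` carries a 3-methylcyclohexyl group and in this assay compound 2 likewise returns a limit, > 10000 nM. Compound 3 `Cc1cccc(C(=O)N2CCc3nc(C#Cc4ccccc4)sc3C2)n1` carries a 6-methylpyridin-2-yl group and in this assay compound 3 also returns a limit, > 10000 nM. Because all three sit at the limit of > 10000 nM in this assay, at which 3 of the 3 values shown sit, none of the steps between them can be sized: a step that the two limits leave unreadable from compound 1 to compound 2, a step that the two limits leave unreadable from compound 1 to compound 3 and a step that the two limits leave unreadable from compound 2 to compound 3. Compound 3 therefore stands where the other two stand, at the limit, with nothing to set it apart.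

Compound 4 `O=C(N1CCCC1)N1CCc2nc(C#Cc3ccccc3)sc2C1` differs from compound 3 in one place: pyrrolidin-1-yl in place of 6-methylpyridin-2-yl on a carbonyl carbon. Among the measured compounds shown here, no measured step gives a readable size, so none points in a direction for this change; together they only show that three different groups on that carbonyl carbon all leave the compound at the limit. The expected step from compound 3 to compound 4 in this assay, an at least 1.1-fold lower number from compound 3 to compound 4 (0.04 log units; that floor lies within the scatter), is accordingly none that can be read beyond the scatter, with a limit again the most likely outcome. Compound 4 is estimated at 9000 nM, within a range from 2000 nM to 30000 nM.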

Compound 4, half-maximal inhibitory concentration: > 10000 nM
Compound 4: only a limit was reported; the forecaster's own chance of this, stated with the estimate: 70%; middle value at least 1.1-fold (0.04 log units) away from the limit.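

Compound 4 also returns only a limit, not a number, so no step linking it to compound 1, compound 2 or compound 3 can be read, and the four stay level at: the limit of > 10000 nM in this assay, at which 4 of the 4 values shown sit.

The compounds shown leave open whether any group on that carbonyl carbon gives a measurable number, and how far apart these four truly lie.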